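A Cyano to Methoxycarbonyl Swap on a Shared Core

The source may hold more compounds than are shown below. What is called first, only, known or untested is meant among the compounds shown, and "the series" means these compounds.

Compound 1 `Cc1c(C#N)c(-c2ccccc2)c(-c2ccccc2)n1CCCCCCNC(=O)Oc1ccccc1` was tested in an assay on microsomes from brain (strain Sprague-Dawley) for inhibition of Fatty-acid amide hydrolase 1 (Rattus norvegicus), read by fluorescence and HPLC, with stated times of 10 min and 60 min (on this read-out lower numbers stand for stronger inhibition and higher numbers for weaker inhibition), where compound 1 gives 8700 nM. Two related compounds carry the same chain and the same terminal group. In this assay compound 2 `O=C(NCCCCCCn1cc(-c2ccccc2)c2ccccc21)Oc1ccccc1` gives 4900 nM, and compound 3 `O=C(NCCCCCCn1c(-c2ccccc2)c(-c2ccccc2)c2ccccc21)Oc1ccccc1` gives 4700 nM. The only single-point step among these three, a 1.0-fold lower number from compound 2 to compound 3 (0.02 log units; within the scatter), changes nothing beyond the scatter. Compound 1 has the highest number of the three, yet its gaps to compound 2 and to compound 3 both fall within the scatter, so the three compounds cannot be told apart on these data.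

Compound 4 `COC(=O)c1c(-c2ccccc2)c(-c2ccccc2)n(CCCCCCNC(=O)Oc2ccccc2)c1C` differs from compound 1 in one place: methoxycarbonyl in place of cyano on an aromatic carbon. For the measured compounds named here, no measured step touches this kind of exchange; the one step available, a 1.0-fold lower number from compound 2 to compound 3 (0.02 log units; within the scatter), concerns a phenyl added elsewhere and says nothing about the group on this ring carbon. With no guidance from the data, no change beyond the scatter is expected, so compound 4 is estimated to give 8000 nM, with a range from 2500 nM to 25000 nM. The expected step of a 1.1-fold lower number from compound 1 to compound 4 (0.04 log units; within the scatter) therefore lies within the scatter, and the range is wide: the exchange itself has not been measured here.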

Compound 4, half-maximal inhibitory concentration: > 10000 nM
Compound 4: only a limit was reported; the forecaster's own chance of this, stated with the estimate: 10%; middle value at least 1.2-fold (0.09 log units) away from the limit.
By their numbers in this assay, from the lowest: compounds 3, 2 and 1 (each within the scatter of the next). At a limit, above all of these: compound 4.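

In this assay compound 4 gives > 10000 nM, which is a limit of the assay and not a number. For the compounds shown here, the step, an at least 1.1-fold higher number from compound 1 to compound 4 (0.06 log units; that floor lies within the scatter), is the first reading of any exchange at this ring carbon, two ring bonds from the ring nitrogen, and it shows that methoxycarbonyl in place of cyano does not bring the number down, even though methoxycarbonyl carries more heavy atoms and one more hydrogen-bond acceptor; the floor of this step lies within the scatter, so it does not by itself separate the two compounds. How far the number really rises stays unknown, since the reading stops at a single value: the limit of > 10000 nM in this assay, at which 1 of the 4 values shown sits.

The compounds shown hold only cyano and methoxycarbonyl on this ring carbon, so it remains open how a carboxylic acid, an amine or a plain hydrogen would read there. As far as these compounds go, it also remains open whether the same exchange would give a similar result with a longer chain in place of the shared chain, or on a core without the methyl group and phenyl groups around this position.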